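The source may hold more compounds than are shown below. What is called first, only, known or untested is meant among the compounds shown, and "the series" means these compounds.

Measured compounds:
compound 1, `COc1cc(-c2cc(/C=C/C(=O)c3ccc(Cl)c(Cl)c3)[nH]n2)cc(OC)c1OC`: 40%
compound 2, `COc1ccc(C(=O)/C=C/c2cc(-c3cc(OC)c(OC)c(OC)c3)n[nH]2)cc1OC`: -91%

In a functional assay on OVCAR-3 cells (Homo sapiens) for cytotoxicity, read by sulforhodamine B assay, with a stated time of 48 h, tested at 10 uM (on this read-out higher numbers stand for a weaker effect at the one concentration tested and lower numbers for a stronger effect), compound 2 gives -91%, the lowest of the two numbers; its nearest neighbour is compound 1, which gives 40%, and the step of a number 131 percentage points lower from compound 1 to compound 2 (beyond the scatter) is large and beyond the scatter. Compound 3, `COc1cc(C(=O)/C=C/c2cc(-c3cc(OC)c(OC)c(OC)c3)n[nH]2)cc(OC)c1OC`, is not yet measured. It differs from compound 2 in one place: methoxy in place of hydrogen on an aromatic carbon. For the measured compounds named here, the only measured step exchanges one aryl group on the carbonyl carbon for another, so no measured step shows the effect of a methoxy in place of hydrogen on this ring, and the step of a number 131 percentage points lower from compound 1 to compound 2 (beyond the scatter) bears on it only in showing that this side of the core can move the read-out strongly. With compound 2 already near the strong end, compound 3 is expected to give a number close to it, and the estimated step of a number 11 percentage points higher from compound 2 to compound 3 (beyond the scatter) is expected to be small. Compound 3 is estimated at -80%, in the range -100% to -30%.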

Compound 3, a percentage reported as activity, at one concentration (the size of the read-out at that concentration, not a potency): -96%
Compound 3: middle estimate off by 16 percentage points, on the high side; measured number inside the range.
By their numbers in this assay, from the lowest: compounds 3 and 2 (each within the scatter of the next); then compound 1.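

In this assay the step of a number 5 percentage points lower from compound 2 to compound 3 (within the scatter) shows that methoxy in place of hydrogen on this aromatic carbon, ortho to a methoxy group and meta to a large group, is tolerated, and that the two compounds cannot be told apart on this read-out. The earlier step of a number 131 percentage points lower from compound 1 to compound 2 (beyond the scatter) showed only that exchanging the whole aryl group on the carbonyl carbon can matter greatly, whereas this result shows that a single added methoxy on that ring need not. Nothing at hand accounts for this result.

On these data alone, whether compound 2 and compound 3 would give a stronger or weaker effect than each other at any other concentration stays open, as the read-out comes from one concentration only. Also open, as far as these compounds go, is how a hydroxyl group, an amine or a longer chain such as ethoxy would fare on this same carbon.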